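The compounds below may be only part of what the source reports. "The series", "measured", "known", "first", "only" and "open" are said of these compounds alone.

Values so far in a functional assay, read by spectrophotometry, with a stated time of 15 min; a higher number here means a weaker inhibitor, a lower number a stronger inhibitor
- compound 1 `Cc1nc2c3ccccc3ccc2c2nc3c(ccc4ccccc43)c(-c3ccccc3Cl)c12` gives 74.6 ug/mL
- compound 2 `Cc1nc2c3ccccc3ccc2c2nc3c(ccc4ccccc43)c(-c3ccc(O)cc3)c12` gives 44.1 ug/mL

Among the compounds with values here, compound 2 cannot be ranked against compound 1, since the only measured step, a 1.7-fold lower number from compound 1 to compound 2 (0.23 log units; within the scatter), exchanged 2-chlorophenyl for 4-hydroxyphenyl. Compound 3 `Cc1nc2c3ccccc3ccc2c2nc3c(ccc4ccccc43)c(-c3ccccc3)c12` departs from compound 2 by one change (hydrogen in place of hydroxy on an aromatic carbon), hydrogen in place of hydroxy on an aromatic carbon. With that single small step as the guide, no shift beyond the scatter is expected in this assay, and no clear direction. The expected change is a 1.2-fold higher number from compound 2 to compound 3 (0.07 log units; within the scatter). Compound 3 is estimated at 52 ug/mL, with an expected range from 24 ug/mL to 110 ug/mL.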

Compound 3, half-maximal inhibitory concentration: 84.6 ug/mL
The estimate for compound 3 lay 1.6-fold (0.21 log units) below the measured number; measured number inside the range.
By their numbers in this assay, from the lowest: compounds 2, 1 and 3 (each within the scatter of the next).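

In this assay, hydrogen in place of hydroxy on the aromatic carbon (4-hydroxyphenyl to phenyl) gave a step within the scatter (a 1.9-fold higher number from compound 2 to compound 3 (0.28 log units; within the scatter)), and hydrogen in place of chloro gave another (a 1.1-fold higher number from compound 1 to compound 3 (0.05 log units; within the scatter)). Plain phenyl therefore cannot be told apart from either substituted phenyl, so neither the hydroxy nor the chloro is shown to matter in this assay. No evidence here bears on this result. Still open, as far as these compounds go, is whether an amine, a carboxylic acid or a longer chain on this ring would move the number beyond the scatter.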